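Butyl in Place of Isopropyl on a Fused Pyrazole Core

A few compounds are considered here, and "the series" means these few. Any claim that something is new, unique, unknown or untested is made for them only; others in the source may bear on it.

Of the compounds shown here, two sharing one core have been tested in a functional assay on the whole organism (strain Holtzman) with Rattus norvegicus as the target; a higher number here means that more compound is needed for the effect, a lower number that less compound is needed. Compound 1, with the structure `CCc1nn(C)c2c1C(c1cccc(F)c1)=NCC(=O)N2`, gives 20 mg/kg in this assay. Compound 2, with the structure `CC(C)c1nn(C)c2c1C(c1ccccc1Cl)=NCC(=O)N2`, is known only by a limit: in this assay compound 2 reaches > 40 mg/kg, which marks the edge of what the test can report rather than a measured number, as noted in the limit of > 40 mg/kg in this assay, at which 1 of the 2 values shown sits. Compound 1 and compound 2 differ in more than one place, so their two values are simply set side by side here and no single change can be read from them.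

Compound 3, with the structure `CCCCc1nn(C)c2c1C(c1ccccc1Cl)=NCC(=O)N2`, has not yet been measured. It differs from compound 2 by a single change: butyl in place of isopropyl on an aromatic carbon. Because compound 2 sits at > 40 mg/kg, the starting point for this change is itself uncertain. With only a limit to build on, the step of a number no higher from compound 2 to compound 3 (the limit leaves the size open) is expected to be small and within the usual scatter. Compound 3 is therefore expected to give about 40 mg/kg in this assay, most likely between 15 mg/kg and 80 mg/kg.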

Compound 3, minimum effective dose: > 40 mg/kg
Compound 3 ended at the assay's limit; the forecaster's own chance of this, stated with the estimate: 50%; the middle value sits exactly at the limit.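

Compound 2 and compound 3 both stop at a limit of the test rather than at a measured number, so no step between them can be read from this assay: the limit of > 40 mg/kg in this assay, at which 2 of the 3 values shown sit.

What the compounds shown leave open is whether butyl in place of isopropyl on an aromatic carbon changes the dose needed at all, in either direction.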